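The compounds below may be only part of what the source reports. "The series", "measured", "known", "first", "only" and "open" are said of these compounds alone.

Compounds measured so far in an ADME assay on liver for metabolic stability, with Liver microsome (Homo sapiens) as the target, read by LC-MS, using microsomes; a higher number here means faster removal of the compound, a lower number slower removal:

- Compound 1 `O=C(NCc1cc(Cl)ccc1-n1cnnn1)[C@@H]1C[C@H]2C[C@H]2N1C(=O)[C@H](O)c1ccccc1` gives < 15 mL.min-1.g-1 (a limit)
- Compound 2 `CC(C)CC[C@@H](O)C(=O)N1N=CC[C@H]1C(=O)NCc1cc(Cl)ccc1-n1cnnn1` gives 47 mL.min-1.g-1
- Compound 3 `O=C(NCc1cc(Cl)ccc1-n1cnnn1)[C@@H]1CCON1C(=O)[C@H](O)c1ccccc1` gives < 12 mL.min-1.g-1 (a limit)

In this assay compound 1 has only a limit (< 15 mL.min-1.g-1) and no number. Compound 3 likewise has only a limit (< 12 mL.min-1.g-1) and no number. Among the three, compound 2 alone gives a number (47 mL.min-1.g-1) in this series.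

Compound 4 `O=C(NCc1cc(Cl)ccc1-n1cnnn1)[C@@H]1C[C@H]2C[C@H]2N1C(=O)[C@H](O)c1cccc(F)c1` has not yet been measured. It differs from compound 1 by one change, phenyl to 3-fluorophenyl: fluoro in place of hydrogen on an aromatic carbon of a six-membered aromatic ring of carbon only, meta to a large group (fluoro in place of hydrogen on an aromatic carbon). Within the data shown here, no two measured compounds differ in one place, so the data offer no direct guide to this change. No step beyond the scatter is expected in this assay and no direction is favoured. The expectation starts from compound 1 and its limit (< 15 mL.min-1.g-1) as the only close reference. The expected step is a step that the limit leaves unreadable from compound 1 to compound 4 by this estimate, and another limit in place of a number would fit it. For compound 4 the estimated value is 14 mL.min-1.g-1 with an expected range from 7 mL.min-1.g-1 to 30 mL.min-1.g-1 as the likely span.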

Compound 4, intrinsic clearance in microsomes: 32 mL.min-1.g-1
Compound 4: the middle estimate sits 2.3-fold (0.36 log units) below what was measured, outside the stated range (above it).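

In this assay, among these compounds, the change from phenyl to 3-fluorophenyl gives the first step in this set between compounds that differ in one place: an at least 2.1-fold higher number from compound 1 to compound 4 (0.32 log units; beyond the scatter). A single fluoro on an aromatic carbon of the six-membered ring, meta to a large group, is therefore enough to carry the read-out beyond the usual scatter, and the step points towards a higher number. The step is only a lower bound, since compound 1 is held by a limit and not by a number: the limit of < 15 mL.min-1.g-1 in this assay, at which 1 of the 4 values shown sits.

The compounds shown leave open whether this step belongs to fluoro itself or would also follow from another group at the same place, such as chloro, methoxy or a nitrile, and whether fluoro elsewhere on the ring would give a step of the same kind. They also cannot tell why the number rises, or whether the same change would give a similar step on the different core of compound 3.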